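The source may hold more compounds than are shown below. What is called first, only, known or untested is meant among the compounds shown, and "the series" means these compounds.

Compound 3 `CCOC(=O)C1=CCCCC1S(=O)(=O)Cc1ccccc1F` is the reference point of this step. In a functional assay on RAW264.7 cells (Mus musculus), read by fluorescence (a lower number here means a stronger inhibitor, a higher number a weaker inhibitor), compound 3 gives 97 nM, the lowest of the two single numbers available, with compound 2 `CCOC(=O)C1=CCCCC1S(=O)(=O)Cc1ccc(Cl)cc1F` nearest: in this assay compound 2 gives 104 nM, and the step of a 1.1-fold lower number from compound 2 to compound 3 (0.03 log units; within the scatter) lies within the scatter. Compound 1 `CCOC(=O)C1=CCCCC1S(=O)(=O)Cc1ccc(F)cc1Cl` has no single number; in this assay compound 1 gives 10 nM; 10000 nM; 5.7 nM (3 entries), and the several entries of compound 1 in this assay, 10 nM; 10000 nM; 5.7 nM (3 entries) shows how far these entries spread, so compound 1 offers no usable comparison.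

Compound 4 `CCOC(=O)C1=CCCCC1S(=O)(=O)Cc1ccc(F)cc1F` is the compound not yet measured. It differs from compound 3 by fluoro in place of hydrogen on an aromatic carbon. For the measured compounds named here, the only measured step that bears on this position is the one from compound 2 to compound 3, where a chloro left the same aromatic carbon and the number stayed within the scatter. A fluoro entering at that carbon is a smaller change than the chloro that left, so the expectation is for no step beyond the scatter in this assay. On that basis compound 4 is estimated at 75 nM, with a range from 25 nM to 250 nM. The expected step of a 1.3-fold lower number from compound 3 to compound 4 (0.11 log units; within the scatter) is therefore small and close to the number for compound 3.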

Compound 4, half-maximal inhibitory concentration: 14 nM
Beside the measured number, compound 4's estimate is 5.4-fold (0.73 log units) above it; measured number below the stated range.
By their numbers in this assay, from the lowest: compound 4; then compounds 3 and 2 (each within the scatter of the next).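

In this assay, the aromatic carbon para to a large group turns out to be sensitive to what stands on it, though only for one of the three substituents compared: a 6.9-fold lower number from compound 3 to compound 4 (0.84 log units; beyond the scatter) with fluoro in place of hydrogen, and this step lies beyond the scatter. Fluoro also separates from chloro at that carbon, with a 7.4-fold lower number from compound 2 to compound 4 (0.87 log units; beyond the scatter), again beyond the scatter, whereas a 1.1-fold lower number from compound 2 to compound 3 (0.03 log units; within the scatter) stays within it, so that among these compounds chloro and hydrogen do not differ and only fluoro stands apart. Any step involving compound 1 cannot be read, and it therefore adds nothing to this comparison: the several entries of compound 1 in this assay, 10 nM; 10000 nM; 5.7 nM (3 entries)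

The compounds shown leave open whether the effect is confined to fluoro or would also appear with another group on that carbon, such as methoxy, nitrile, trifluoromethyl or an amine. They also leave open whether the same step would appear with the other fluoro group on the ring taken away, and what lies behind the step at all.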